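Ester to Acid: Cytotoxicity Expected Unchanged

The compounds below may be only part of what the source reports. "The series", "measured", "known", "first", "only" and "open" are said of these compounds alone.

Compound 3 `CCOC(=O)c1cn(COCCO)c2cc(Cl)ccc2c1=O` has been tested in a functional assay on Vero cells (Chlorocebus sabaeus) for cytotoxicity, read by MTT assay (a lower number here means that less compound is tolerated, a higher number that more compound is tolerated), where compound 3 gives 1200000 nM. For the measured compounds named here, only two numbers were actually read in this assay, and compound 3 stands within the scatter of the other one, compound 2 `CCOC(=O)c1cn(COCCO)c2ccc(Cl)cc2c1=O`, which gives 1250000 nM. Compound 1 `CCOC(=O)c1cn(COCCO)c2ccc(F)cc2c1=O` yields only a limit in this assay, > 500000 nM. The size of the step from compound 1 to compound 2, a step that the limit leaves unreadable from compound 1 to compound 2, therefore cannot be read, because of the limit of > 500000 nM in this assay, at which 1 of the 3 values shown sits.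

Compound 4 `O=C(O)c1cn(COCCO)c2cc(Cl)ccc2c1=O` has not yet been measured. It differs from compound 3 by hydrogen in place of ethyl on an oxygen next to a carbonyl group. Going by the values given here, no measured step touches this part of the molecule: the only step available, fluoro to chloro on an aromatic carbon, leaves the ethoxycarbonyl group untouched, and it cannot be sized in any case. There is thus no measured basis for a shift in either direction, and the step of no change at the digits printed from compound 3 to compound 4 (within the scatter) is expected to remain within the scatter, with some chance that this assay again returns only a limit. Compound 4 is accordingly estimated at 1200000 nM, with a range from 400000 nM to 3500000 nM in this assay.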

Compound 4, half-maximal cytotoxic concentration: 1200000 nM
The estimate for compound 4 equals the measured number at the digits printed, within the range that was stated.
By their numbers in this assay, from the lowest: compounds 3, 4 and 2 (each within the scatter of the next).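

In this assay, the exchange of ethoxycarbonyl for carboxy reads as no change at the digits printed from compound 3 to compound 4 (within the scatter). For the compounds shown here, this is the first readable step at this place on the shared core, since compounds 1, 2 and 3 all carry the same ethoxycarbonyl group, and it shows that, in this one pair, losing the ethyl group and its 2 heavy atoms in favour of a hydrogen leaves the two numbers within the scatter of each other. The only earlier step between compounds that differ in one place, chloro in place of fluoro, still gives no size for comparison, and it cannot be read because compound 1 carries a limit: the limit of > 500000 nM in this assay, at which 1 of the 4 values shown sits.

The compounds shown leave open whether a primary amide or a longer alkyl ester in place of the ethyl ester would also stay within the scatter of compound 3. They also leave open whether the same exchange of ethyl for hydrogen would read alike on compound 1 or compound 2, so a single pair supports no wider pattern.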